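This account rests on a few compounds, and the source may have more. Where it says the series, first, only, none or still open, it means among the compounds named here.

Compound 1 `CCCCSc1nsnc1[C@@H]1CN2CCC[C@@H]1C2`: in a functional assay on the whole organism for inhibition, with Rattus norvegicus as the target (on this read-out lower numbers stand for an effect already at smaller amounts and higher numbers for an effect only at larger amounts of compound), compound 1 gives > 3 mg/kg, which is a limit of the assay rather than a number.
Compound 2 `CCCCSc1nsnc1[C@@H]1CN2CCC[C@H]1C2`: compound 2 gives 0.018 mg/kg.
Compound 3 `CCSc1nsnc1C1CN2CCC[C@H]1C2`: compound 3 gives 0.045 mg/kg.

Compound 3 thus holds the highest of the two numbers shown; its nearest neighbour is compound 2, and that gap lies beyond the scatter. Compound 4 `CCCCCCSc1nsnc1C1CN2CCC[C@H]1C2` differs from compound 3 by butyl in place of hydrogen on a saturated chain carbon, two bonds along the chain from a sulfur. Among the measured compounds shown here, the one measured step, an at least 160-fold lower number from compound 1 to compound 2 (2.22 log units; beyond the scatter), concerns a stereocentre rather than the chain, so it does not bear on this change. For the measured compounds named here, compounds 2 and 3, for which no single step is drawn, show values that are not far apart. Compound 4 is therefore expected to move little, with a 1.3-fold higher number from compound 3 to compound 4 (0.12 log units; within the scatter). The estimate for compound 4 is 0.06 mg/kg, within 0.015 mg/kg to 0.25 mg/kg.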

Compound 4, dose for half-maximal effect: 0.1 mg/kg
Estimate against measurement, compound 4: 1.7-fold (0.22 log units) below; low and high end bracket the measured number.
By their numbers in this assay, from the lowest: compound 2; then compound 3; then compound 4. At a limit, above all of these: compound 1.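

Butyl in place of hydrogen on a saturated chain carbon, two bonds along the chain from a sulfur, which reads as ethyl to hexyl, gives a 2.2-fold higher number from compound 3 to compound 4 (0.35 log units; beyond the scatter) in this assay. Among the compounds shown here, this is the first measured step at the chain, since the earlier step concerned only a stereocentre, and it shows that this position responds modestly to lengthening. No measurement given here explains this step. The compounds shown leave open how a shorter methyl chain, or a chain ending in an amine or a carboxylic acid, would behave.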